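The source may report more compounds than this note shows. Statements on the series, on what has been measured and on what is new or still open speak of the compounds shown alone.

Measured so far in a functional assay on MDA-MB-231 cells (Homo sapiens) for antiproliferative activity, read by MTT assay, with a stated time of 72 h; on this read-out higher numbers stand for weaker inhibition and lower numbers for stronger inhibition:

compound 1, `CN(C)CCn1cnnc1-c1cc(Oc2ccc(NC(=O)Nc3ccc(F)c(F)c3)cc2F)ccn1`: > 50000 nM, a limit of the assay.
compound 2, `CN(C)CCn1cnnc1-c1cc(Oc2ccc(NC(=O)Nc3ccc(F)c(Cl)c3)cc2F)ccn1`: 8320 nM.
compound 3, `CCN(CC)CCn1cnnc1-c1cc(Oc2ccc(NC(=O)Nc3ccc(F)c(F)c3)cc2F)ccn1`: 41300 nM.

Compound 1 is reported by this assay only as a limit, namely (the limit of > 50000 nM in this assay, at which 1 of the 3 values shown sits). Compound 2 gives 8320 nM. The step between them, an at least 6.0-fold lower number from compound 1 to compound 2 (0.77 log units; beyond the scatter), corresponds to chloro in place of fluoro on an aromatic carbon; it can be given only as a floor because compound 1 sits at the limit of > 50000 nM in this assay, at which 1 of the 3 values shown sits.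

Compound 3 gives 41300 nM. The step of an at least 1.2-fold lower number from compound 1 to compound 3 (0.08 log units; that floor lies within the scatter) corresponds to diethylamino in place of dimethylamino on a saturated chain carbon, two bonds along the chain from an aromatic nitrogen, and its floor lies within the scatter, so no change between compound 1 and compound 3 can be claimed. Among the measured compounds shown here, of the two numbers, the one for compound 2 is lower than the one for compound 3, beyond the scatter.

Compound 4, `CCN(CC)CCn1cnnc1-c1cc(Oc2ccc(NC(=O)Nc3ccc(F)c(Cl)c3)cc2F)ccn1`, has not been measured in this assay. It differs from compound 3 by chloro in place of fluoro on an aromatic carbon. For the measured compounds named here, this is the same change, at the same place, as the one from compound 1 to compound 2; the two cores differ by diethylamino in place of dimethylamino on a saturated chain carbon, two bonds along the chain from an aromatic nitrogen.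

For compound 4 a step of about a 5.9-fold lower number from compound 3 to compound 4 (0.77 log units; beyond the scatter) is expected, set beside the earlier at least 6.0-fold lower number from compound 1 to compound 2 (0.77 log units; beyond the scatter), because the same change gave an at least 6.0-fold lower number from compound 1 to compound 2 (0.77 log units; beyond the scatter) on the core of compound 1, and the two cores showed no resolvable difference in an at least 1.2-fold lower number from compound 1 to compound 3 (0.08 log units; that floor lies within the scatter). Compound 4 is therefore estimated at 7000 nM in this assay, expected to lie between 2500 nM and 20000 nM.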

Compound 4, half-maximal inhibitory concentration: 34000 nM
Estimate against measurement, compound 4: 4.9-fold (0.69 log units) below; the measured number lies above the stated range.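

In this assay, chloro in place of fluoro on the 3,4-difluorophenyl group gives a 1.2-fold lower number from compound 3 to compound 4 (0.08 log units; within the scatter), so the step seen with the dimethylamino chain does not carry over to the diethylamino chain: the same change on two cores in this assay, an at least 6.0-fold lower number (0.77 log units; beyond the scatter) from compound 1 to compound 2 and a 1.2-fold lower number (0.08 log units; within the scatter) from compound 3 to compound 4, at least 4.9-fold (0.69 log units) apart, beyond the scatter of two such steps

Read along the other edge of the same square, diethylamino in place of dimethylamino gives a 4.1-fold higher number from compound 2 to compound 4 (0.61 log units; beyond the scatter) among the 3-chloro-4-fluorophenyl compounds, while no change can be claimed among the 3,4-difluorophenyl compounds, and the two changes therefore do not add up independently across these four compounds: the same change on two cores in this assay, an at least 1.2-fold lower number (0.08 log units; that floor lies within the scatter) from compound 1 to compound 3 and a 4.1-fold higher number (0.61 log units; beyond the scatter) from compound 2 to compound 4, at least 4.9-fold (0.69 log units) apart, beyond the scatter of two such steps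

Compound 1 is held only as a limit, so both gaps are floors rather than sizes, and neither what separates the two cores nor whether the behaviour holds on any further core is shown: the limit of > 50000 nM in this assay, at which 1 of the 4 values shown sits.

Open, as far as these compounds go, is whether the chloro step survives with other amines at the end of the chain, such as pyrrolidine or morpholine, or with a longer chain carrying the same dimethylamino or diethylamino group. Also open, from the compounds shown here alone, is whether bromo or trifluoromethyl in place of the chloro would depend on the amine in the same way.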